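Compound 3 to compound 4: 4-bromophenyl to 4-iodophenyl

A few compounds are considered here, and "the series" means these few. Any claim that something is new, unique, unknown or untested is made for them only; others in the source may bear on it.

Measured so far in an ADME assay on MDBK cells (Bos taurus) for cytotoxicity; on this read-out lower numbers stand for higher toxicity in this test and higher numbers for lower toxicity in this test:
Compound 1 `Fc1ccccc1Cn1ccc2nc(-c3ccccc3)nc-2c1`: > 100000 nM (a limit of the assay)
Compound 2 `Brc1ccccc1Cn1ccc2nc(-c3ccccc3)nc-2c1`: > 100000 nM (a limit of the assay)
Compound 3 `Brc1ccc(Cn2ccc3nc(-c4ccccc4)nc-3c2)cc1`: 83000 nM

Among the measured compounds shown here, compound 3 gives the only true number in this assay, at 83000 nM. Compound 1 and compound 2 stand at the limit of > 100000 nM in this assay, at which 2 of the 3 values shown sit.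

Compound 4 `Ic1ccc(Cn2ccc3nc(-c4ccccc4)nc-3c2)cc1` carries iodo in place of bromo on an aromatic carbon.

The nearest measured swap of one halogen for another is a step that the two limits leave unreadable from compound 1 to compound 2, so it offers no size to carry over. The two steps that reach the 4-bromophenyl are an at least 1.2-fold lower number from compound 1 to compound 3 (0.08 log units; that floor lies within the scatter) and an at least 1.2-fold lower number from compound 2 to compound 3 (0.08 log units; that floor lies within the scatter). Both have floors inside the scatter, so they set no size either.

With no readable halogen step, no change beyond the scatter is expected, and the estimate stays close to compound 3 at 83000 nM. The estimated step is a 1.1-fold lower number from compound 3 to compound 4 (0.04 log units; within the scatter). Compound 4 is expected at 75000 nM, with an estimated range of 40000 nM to 100000 nM.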

Compound 4, half-maximal cytotoxic concentration: 22000 nM
For compound 4 the middle estimate is 3.4-fold (0.53 log units) above the measured one, and the stated range ends above it.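

Iodo in place of bromo on this aromatic carbon, para to a large group, gives the first halogen swap of readable size in this assay (a 3.8-fold lower number from compound 3 to compound 4 (0.58 log units; beyond the scatter)). The 4-iodophenyl group also separates from the 2-bromophenyl group (an at least 4.5-fold lower number from compound 2 to compound 4 (0.65 log units; beyond the scatter)) and from the 2-fluorophenyl group (an at least 4.5-fold lower number from compound 1 to compound 4 (0.65 log units; beyond the scatter)), both beyond the scatter, whereas the floors of the steps to the 4-bromophenyl compound stayed within it. At this position, then, the choice of halogen can shift the read-out, at least between bromo and iodo.

The full size of the steps from compound 1 and compound 2 stays open, because each of these compounds sits at a limit: the limit of > 100000 nM in this assay, at which 2 of the 4 values shown sit. Going by these compounds, whether a nitrile, an amine or a carboxylic acid on this carbon would give a similarly low number also remains open.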